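A few compounds are considered here, and "the series" means these few. Any claim that something is new, unique, unknown or untested is made for them only; others in the source may bear on it.

The compounds measured in an in vitro functional assay on HEK293-A cells for antagonist activity at metabotropic glutamate receptor 5 (Rattus norvegicus), read by calcium flux; on this read-out higher numbers stand for weaker inhibition and lower numbers for stronger inhibition:
Compound 1, `Cc1cccc(NC(=O)c2cc(F)cc(C#N)c2)c1`, gives 122 nM.
Compound 2, `CC(C)(C)c1cccc(NC(=O)c2cc(F)cc(C#N)c2)c1`, gives only an assay limit, > 30000 nM.

Compound 2 therefore stands at the weak end of what this assay reports, with no exact number; this is the limit of > 30000 nM in this assay, at which 1 of the 2 values shown sits. Compound 3, `CS(=O)(=O)c1cccc(NC(=O)c2cc(F)cc(C#N)c2)c1`, differs from compound 2 by methylsulfonyl in place of tert-butyl on an aromatic carbon. For the measured compounds named here, the only measured step touching this site is an at least 240-fold higher number from compound 1 to compound 2 (2.39 log units; beyond the scatter), a large loss. Going by the values given here, no measured compound carries methylsulfonyl, so the expected size is uncertain. Compound 3 is expected to give 6000 nM, within 600 nM to 30000 nM. The estimated step is an at least 5.0-fold lower number from compound 2 to compound 3 (0.69 log units; beyond the scatter).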

Compound 3, half-maximal inhibitory concentration: > 30000 nM
Compound 3: no number, only a limit (the forecaster's own chance of this, stated with the estimate: 40%); at least 5.0-fold (0.69 log units) between middle value and limit.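

Methylsulfonyl in place of methyl on this aromatic carbon gives an at least 240-fold higher number from compound 1 to compound 3 (2.39 log units; beyond the scatter), so the loss seen with tert-butyl also appears with a group that carries hydrogen-bond acceptors and no longer consists of carbon only. In this assay compound 3 gives > 30000 nM, which is a limit of the assay and not a number. The step between compound 2 and compound 3 cannot be read, and the compounds shown now gather at one end of the scale: the limit of > 30000 nM in this assay, at which 2 of the 3 values shown sit.

As far as these compounds go, whether ethyl, methoxy or chlorine at this place would stay close to compound 1 remains open. So does the outcome with an amine there.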